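A few compounds are considered here, and "the series" means these few. Any claim that something is new, unique, unknown or untested is made for them only; others in the source may bear on it.

Working notes on the prenylated chalcone series.

Compound 1 `COc1cc(OC)c(C(=O)/C=C/c2cccc(N3CCNCC3)c2)c(O)c1CC=C(C)C` and compound 3 `COc1cc(OC)c(C(=O)/C=C/c2ccc(N3CCNCC3)cc2)c(O)c1CC=C(C)C` share the same atoms joined differently; the difference between the two cores is not broken down here. In an ADME assay on MCF7-DOX cells (Homo sapiens) for cytotoxicity, read by MTT assay, with a stated time of 48 h (on this read-out lower numbers stand for stronger inhibition and higher numbers for weaker inhibition), compound 1 gives 99900 nM and compound 3 gives 57800 nM, two values that lie within the scatter of each other, so no order between them is drawn.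

Compound 2 `COc1cc(OC)c(C(=O)/C=C/c2ccc(N3CCN(C(=O)OC(C)(C)C)CC3)cc2)c(O)c1CC=C(C)C` in this assay reaches only a limit, > 100000 nM, and reports no number. Compound 2 comes from compound 3 by tert-butoxycarbonyl in place of hydrogen on an amine nitrogen in a ring. This change moved the read-out an at least 1.7-fold higher number from compound 3 to compound 2 (0.23 log units; that floor lies within the scatter), a floor set by the limit of > 100000 nM in this assay, at which 1 of the 3 values shown sits.

Compound 4 `COc1cc(OC)c(C(=O)/C=C/c2cccc(N3CCN(C(=O)OC(C)(C)C)CC3)c2)c(O)c1CC=C(C)C` is not yet measured. It comes from compound 1 by tert-butoxycarbonyl in place of hydrogen on an amine nitrogen in a ring, the same change as from compound 3 to compound 2, at a place described in the same words. For compound 4 in this assay a step of a 1.5-fold higher number from compound 1 to compound 4 (0.18 log units; within the scatter) is expected, resting on the step from compound 3 to compound 2 an at least 1.7-fold higher number from compound 3 to compound 2 (0.23 log units; that floor lies within the scatter) and on compound 1 already standing at 99900 nM. The estimate for compound 4 in this assay is 150000 nM, most likely reported as a limit rather than a number.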

Compound 4, half-maximal inhibitory concentration: 42600 nM
The estimate for compound 4 lay 3.5-fold (0.55 log units) above the measured number, and the stated range ends above it.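

In this assay, tert-butoxycarbonyl in place of hydrogen on an amine nitrogen in a ring gives a 2.3-fold lower number from compound 1 to compound 4 (0.37 log units; beyond the scatter), a modest step, and the change does not carry over from one core to the other as a single fixed step: the same change on two cores in this assay, an at least 1.7-fold higher number (0.23 log units; that floor lies within the scatter) from compound 3 to compound 2 and a 2.3-fold lower number (0.37 log units; beyond the scatter) from compound 1 to compound 4, at least 4.0-fold (0.60 log units) apart, beyond the scatter of two such steps

The value of compound 2, > 100000 nM, is a limit and not a number, so the earlier step is known only as a floor: the limit of > 100000 nM in this assay, at which 1 of the 4 values shown sits.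

With one pair on each core, this shows that the result of the change depends on the core in these four compounds, but it does not show why, nor how the change would behave on any further core.

From the compounds shown here alone, it remains open whether a smaller group on the same ring nitrogen, such as acetyl or methyl, would follow the step to compound 4 or the step to compound 2. Also open, going by these compounds, is whether an open-chain amine could stand in place of the six-membered ring with 2 nitrogen on either core.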